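Alkenyl amides in place of chloroethenyl: next step

A few compounds are considered here, and "the series" means these few. Any claim that something is new, unique, unknown or untested is made for them only; others in the source may bear on it.

The series shares one core; compound 1 `C=C(Cl)C(=O)Nc1cc(Nc2nccc(-c3cn(C)c4ccccc34)n2)c(OC)cc1N(C)CCN(C)C` carries a 1-chloroethenyl on the amide carbonyl carbon and gives 1390 nM in a functional assay on HepG2 cells (Homo sapiens) for antiproliferative activity, read by MTT assay, with a stated time of 72 h; a higher number here means a weaker inhibitor, a lower number a stronger inhibitor. Compound 2 `COc1cc(N(C)CCN(C)C)c(NC(=O)/C=C\C(C)C)cc1Nc1nccc(-c2cn(C)c3ccccc23)n1` gives 4390 nM, and compound 3 `C=C(Cl)C(=O)Nc1cc(Nc2nc(C)cc(-c3cn(C)c4ccccc34)n2)c(OC)cc1N(C)CCN(C)C` gives 3640 nM. Among the three numbers compound 3 stands second highest; its gap to compound 2 lies within the scatter, while the step of a 2.6-fold higher number from compound 1 to compound 3 (0.42 log units; beyond the scatter) lies beyond it and came with methyl in place of hydrogen on an aromatic carbon.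

Compound 4 `CCC/C=C\C(=O)Nc1cc(Nc2nc(C)cc(-c3cn(C)c4ccccc34)n2)c(OC)cc1N(C)CCN(C)C` is not yet measured. It differs from compound 3 in one place: pent-1-en-1-yl in place of 1-chloroethenyl on a carbonyl carbon.

The measured step that bears on this exchange is a 3.2-fold higher number from compound 1 to compound 2 (0.50 log units; beyond the scatter), where an alkenyl group likewise took the place of 1-chloroethenyl on the carbonyl carbon. The step of a 2.6-fold higher number from compound 1 to compound 3 (0.42 log units; beyond the scatter) only fixes the starting point of compound 3. On that basis a modest rise in the number, of about the size seen from compound 1 to compound 2, is expected for compound 4, that is a 2.6-fold higher number from compound 3 to compound 4 (0.42 log units; beyond the scatter).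

Compound 4 is therefore estimated at 9500 nM in this assay, with an expected range from 3500 nM to 25000 nM.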

Compound 4, half-maximal inhibitory concentration: 365 nM
Beside the measured number, compound 4's estimate is 26-fold (1.42 log units) above it; the whole stated range lies above it.
By their numbers in this assay, from the lowest: compound 4; then compound 1; then compounds 3 and 2 (each within the scatter of the next).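

In this assay the exchange on the carbonyl carbon runs the opposite way to the earlier case: a 10-fold lower number from compound 3 to compound 4 (1.00 log units; beyond the scatter) with pent-1-en-1-yl in place of 1-chloroethenyl, against a 3.2-fold higher number from compound 1 to compound 2 (0.50 log units; beyond the scatter) with 3-methylbut-1-en-1-yl in that place. Within the data shown here, an alkenyl in place of 1-chloroethenyl therefore has no single direction here, and this position can shift the number either way by steps beyond the scatter, the new step being the largest so far; the two steps differ both in the entering alkenyl and in the presence of the methyl on the aromatic carbon in the starting compound. Nothing available on these compounds accounts for the reversal.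

Open, on these data alone, is whether the fall belongs to pent-1-en-1-yl itself or depends on that aromatic methyl, which would take pent-1-en-1-yl on the core of compound 1 and 3-methylbut-1-en-1-yl on the core of compound 3 to separate. Also open, as far as these compounds go, is how the number responds to a longer chain such as hept-1-en-1-yl, or to an alkenyl chain ending in an amine such as dimethylamino.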